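The source may report more compounds than this note shows. Statements on the series, on what has been measured and on what is new or still open speak of the compounds shown alone.

Compound 2 `CCCCCc1cc2ccccc2nc1-c1cn(CCC(F)(F)C(F)(F)C(F)(F)C(F)(F)C(F)(F)C(F)(F)C(F)(F)C(F)(F)F)nn1` is the reference point for this step. In a functional assay on HeLa cells (Homo sapiens) for cytotoxicity, read by MTT assay, with a stated time of 24 h (a lower number here means a stronger inhibitor, a higher number a weaker inhibitor), compound 2 gives only a limit, > 100 ug/mL. Compound 1 `CCCCCCCCCCn1cc(-c2nc3ccccc3cc2CC)nn1` likewise reaches only a limit in this assay, > 100 ug/mL. Compound 3 `CCCCCCCCCCn1cc(-c2nc3ccccc3cc2CCCCC)nn1` also stands at a limit, > 100 ug/mL. Going by the values given here, the one measured change, a step that the two limits leave unreadable from compound 1 to compound 3, cannot be sized because of the limit of > 100 ug/mL in this assay, at which 3 of the 3 values shown sit. Compound 4 `CCCc1cc2ccccc2nc1-c1cn(CCC(F)(F)C(F)(F)C(F)(F)C(F)(F)C(F)(F)C(F)(F)C(F)(F)C(F)(F)F)nn1` differs from compound 2 by hydrogen in place of ethyl on a saturated chain carbon, three bonds along the chain from an aromatic carbon. Among the compounds with values here, no measured step bears on this particular change, and the shortening of the chain on the same carbon in the measured pair gives no readable size. Compound 4 is therefore expected to stay at the same limit, an expected step that the limit leaves unreadable from compound 2 to compound 4. The estimate for compound 4 is 150 ug/mL, ranging from 40 ug/mL to 500 ug/mL.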

Compound 4, half-maximal inhibitory concentration: 37.8 ug/mL
Estimate against measurement, compound 4: 4.0-fold (0.60 log units) above; measured number below the stated range.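

In this assay, going by these compounds alone, going from the pentyl of compound 2 to the propyl of compound 4, with the rest of the molecule unchanged, gives an at least 2.6-fold lower number from compound 2 to compound 4 (0.42 log units; beyond the scatter), the first step here that can be sized. Within the data shown here, it shows that the number at this position does respond to chain length, which the earlier compounds could not show: the limit of > 100 ug/mL in this assay, at which 3 of the 4 values shown sit. Compound 2 gives only a limit, so this step's true size remains unfixed.

From the compounds shown here alone, whether a methyl or an amine in place of the propyl would lower the number further stays open. So does whether a propyl would have any such effect with the other chain on the triazole-bearing side, the one carried by compound 3.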